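The source may report more compounds than this note shows. Statements on the series, on what has been measured and on what is new or still open speak of the compounds shown alone.

Of the compounds shown here, three built on one shared core have been tested in a functional assay on BGC-823 cells (Homo sapiens) for antiproliferative activity, read by MTT assay, tested at 1 uM; a lower number here means a weaker effect, a higher number a stronger effect of the compound at the concentration tested. Compound 1 `COc1cc(C2=NN(C(C)=O)C(c3cccc(OC)c3OC)O2)cc(OC)c1OC` gives 3.8% in this assay. Compound 2 `COc1ccc(C2OC(c3cc(OC)c(OC)c(OC)c3)=NN2C(C)=O)c(OC)c1` gives 6.3%. Compound 3 `COc1cc(C2=NN(C(C)=O)C(c3ccc(C(F)(F)F)cc3)O2)cc(OC)c1OC` gives 4.2%. As to where compound 3 stands: its number lies nearest to that of compound 1, the step being a number 0.4 percentage points higher from compound 1 to compound 3 (within the scatter), and furthest from that of compound 2, the step being a number 2.1 percentage points lower from compound 2 to compound 3 (within the scatter); both steps lie within the scatter, so none of the three compounds can be set apart from the others. The remaining step, a number 2.5 percentage points higher from compound 1 to compound 2 (within the scatter), is likewise within the scatter. All three steps are exchanges of the aryl group on a saturated ring carbon of the shared core, and so all three bear on the change considered next.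

Compound 4 `COc1cc(C2=NN(C(C)=O)C(c3ccc(Cl)c([N+](=O)[O-])c3)O2)cc(OC)c1OC` differs from compound 3 by 4-chloro-3-nitrophenyl in place of 4-(trifluoromethyl)phenyl on a saturated ring carbon. Because a number 0.4 percentage points higher from compound 1 to compound 3 (within the scatter) and a number 2.1 percentage points lower from compound 2 to compound 3 (within the scatter) both stayed within the scatter, the expectation for this further exchange at the same saturated ring carbon is no step beyond the scatter, that is a number 0.8 percentage points higher from compound 3 to compound 4 (within the scatter). Compound 4 is therefore estimated to give 5% in this assay, with a range from 0% to 15%.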

Compound 4, a percentage reported as inhibition, at one concentration (the size of the read-out at that concentration, not a potency): -2.3%
Compound 4: middle estimate off by 7.3 percentage points, on the high side; measured number below the stated range.
By their numbers in this assay, from the lowest: compounds 4, 1, 3 and 2 (each within the scatter of the next).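

Among these compounds, at the saturated ring carbon, bringing in 4-chloro-3-nitrophenyl, the first aryl group here with nitrogen, oxygen and chlorine among its atoms, leaves the picture in this assay unchanged: the exchange gives a number 6.5 percentage points lower from compound 3 to compound 4 (within the scatter) and the comparisons with the two dimethoxyphenyl compounds give a number 8.6 percentage points lower from compound 2 to compound 4 (within the scatter) and a number 6.1 percentage points lower from compound 1 to compound 4 (within the scatter) as well. Among the compounds shown here, these steps are wider than any seen among the earlier compounds, yet none of them separates compound 4 from the rest, so four different aryl groups at this position now cannot be told apart at the single concentration tested. Nothing available explains the size of these steps or links them to any feature of the entering group.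

The compounds shown leave open whether any aryl group at this carbon can lift the read-out clear of the scatter, for instance one carrying an amine or a carboxylic acid, or whether a longer alkyl chain in place of the aryl ring would do so. They also leave open what a longer chain in place of the acetyl group on the ring nitrogen would do, since that group is the same in all four compounds.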